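Aminocarbamoyl in place of hydroxymethyl in compound 2

The source may hold more compounds than are shown below. What is called first, only, known or untested is meant among the compounds shown, and "the series" means these compounds.

Measured in an ADME assay on TZM cells (Homo sapiens) for cytotoxicity, read by XTT assay, with a stated time of 4 days; a lower number here means that less compound is tolerated, a higher number that more compound is tolerated:
Compound 1 `Cc1cc(CCC#N)cc(C)c1Oc1cc(Nc2ccc(C#N)cc2)c(N)cc1N`: > 25000 nM (a limit)
Compound 2 `Cc1cc(CCC#N)cc(C)c1Oc1cc(Nc2ccc(C#N)cc2)c(N)cc1CO`: > 23800 nM (a limit)

Compound 2 stands at a limit and has no number: > 23800 nM. Compound 1 also stands at a limit: > 25000 nM. Neither value therefore gives a true reading in this assay.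

Compound 3 `Cc1cc(CCC#N)cc(C)c1Oc1cc(Nc2ccc(C#N)cc2)c(N)cc1C(=O)NN` follows from compound 2 by one change: aminocarbamoyl in place of hydroxymethyl on an aromatic carbon. This puts aminocarbamoyl in place of hydroxymethyl on an aromatic carbon, para to a (4-cyanophenyl)amino group.

For the measured compounds named here, only one measured step bears on this change: a step that the two limits leave unreadable from compound 1 to compound 2. It also exchanges a group on an aromatic carbon, but it offers no size to carry over. No step beyond the usual scatter is therefore expected, and no direction can be favoured. The assay may well report only a limit again. The step expected on these grounds is a step that the limit leaves unreadable from compound 2 to compound 3. For compound 3 the estimated value is 24000 nM, with an expected range from 10000 nM to 50000 nM.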

Compound 3, half-maximal cytotoxic concentration: > 22700 nM
Compound 3: no number, only a limit; the forecaster's own chance of this, stated with the estimate: 75%; the middle value is on the limit's open side.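

In this assay compound 3 gives > 22700 nM, which is a limit and not a number. For the compounds shown here, compound 1, compound 2 and compound 3 all stand at limits, and no step among them can be read. The compounds shown leave open whether amino, hydroxymethyl or aminocarbamoyl on this aromatic carbon makes any difference to the cytotoxic concentration.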